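Replacing methylsulfanyl with methylsulfonyl in compound 2

The source may report more compounds than this note shows. Statements on the series, on what has been measured and on what is new or still open speak of the compounds shown alone.

Of the compounds shown here, two with different cores have so far been measured in a functional assay on the whole organism with Canis familiaris (Canis lupus familiaris) as the target; on this read-out lower numbers stand for an effect already at smaller amounts and higher numbers for an effect only at larger amounts of compound. Compound 1 `COc1cc(SC)ccc1-c1nc2cc[nH]cc-2n1` gives 0.2 mg/kg, and compound 2 `COc1cc(SC)ccc1-c1cn2ccncc2n1` gives 0.5 mg/kg. Compound 2 thus holds the higher of the two numbers, and its gap to compound 1 lies beyond the usual scatter of such measurements. Both compounds carry the methylsulfanyl group, so neither shows what happens when that group is replaced.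

Compound 3 `COc1cc(S(C)(=O)=O)ccc1-c1cn2ccncc2n1` keeps the core of compound 2 but has methylsulfonyl in place of methylsulfanyl on an aromatic carbon, meta to a methoxy group (methylsulfonyl in place of methylsulfanyl on an aromatic carbon). Among the measured compounds shown here, no measured pair shows this change, so any forecast has little support from the data. A modest move towards a higher number in this assay is expected, perhaps not beyond the scatter, and a move the other way cannot be ruled out. The estimated step is a 1.6-fold higher number from compound 2 to compound 3 (0.20 log units; within the scatter). For compound 3 the estimated dose is 0.8 mg/kg, with an expected range from 0.2 mg/kg to 3 mg/kg.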

Compound 3, dose for half-maximal effect: 0.02 mg/kg
Compound 3: the middle estimate sits 40-fold (1.60 log units) above what was measured, and the stated range ends above it.
By their numbers in this assay, from the lowest: compound 3; then compound 1; then compound 2.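

In this assay, placing methylsulfonyl instead of methylsulfanyl on the aromatic carbon, meta to a methoxy group, gives a 25-fold lower number from compound 2 to compound 3 (1.40 log units; beyond the scatter) on an otherwise unchanged structure. The earlier compounds shown here both carried methylsulfanyl and so gave no view of this position, which now proves highly sensitive to the group placed there: a single change, with no alteration to the core, moves the dose needed for half-maximal effect markedly lower. The result also shows that the two added oxygens of methylsulfonyl, with the group growing from 2 to 4 heavy atoms, are accompanied by a gain rather than a loss on this read-out, although nothing in the data explains the size of the step.

The compounds shown leave open whether the same change would produce a step of similar size on the core of compound 1, where only methylsulfanyl appears. They also do not show how other groups at this position would compare, such as methylsulfinyl, a sulfonamide or a carboxylic acid, so it remains unclear whether the gain is specific to methylsulfonyl.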